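The source may hold more compounds than are shown below. What is called first, only, known or untested is meant among the compounds shown, and "the series" means these compounds.

Working notes on the series in an in vitro assay on BTI-TN-5B1-4 cells for inhibition of Amine oxidase [flavin-containing] B (Homo sapiens), tested at 100 uM; on this read-out lower numbers stand for less inhibition and higher numbers for more inhibition at the one concentration tested (going by the name of the read-out). Compound 1 `Fc1ccc2c(=S)cc(-c3ccccc3)oc2c1` serves as the first anchor: in this assay compound 1 gives 40%. Compound 2 `COc1ccc(-c2cc(=S)c3ccc(C)cc3o2)cc1` is the second measured point, and in this assay compound 2 gives 40%. On the numbers shown, compound 2 stands level with compound 1 at the digits recorded; its nearest neighbour is compound 1, and the two values lie within the scatter of each other, so no order between them is claimed. Among the compounds with values here, compound 1 and compound 2 differ in more than one place, and no single-point step between them is available; their two values simply show the same inhibition.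

Compound 3 `COc1ccc(-c2cc(=S)c3ccc(F)cc3o2)cc1` is not yet measured. Against compound 2 its change is fluoro in place of methyl on an aromatic carbon, with the fluoro entering where the methyl leaves, on an aromatic carbon of a six-membered aromatic ring of carbon only, part of a fused system of two rings. Because compound 1, which carries fluoro at that position, gives 40%, and compound 2 gives 40%, no step beyond the scatter is expected; the expected step is no change at the digits printed from compound 2 to compound 3 (within the scatter). Compound 3 is accordingly estimated at 40%, with a range from 25% to 55%.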

Compound 3, a percentage reported as inhibition, at one concentration (the size of the read-out at that concentration, not a potency): 40%
The estimate for compound 3 equals the measured number at the digits printed; the measured number falls inside the stated range.
By their numbers in this assay, from the lowest: compounds 1, 2 and 3 (each within the scatter of the next).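

In this assay the exchange of methyl for fluoro on an aromatic carbon of the six-membered aromatic ring of carbon only, part of the fused system of two rings, reads as no change at the digits printed from compound 2 to compound 3 (within the scatter) with the methoxy group kept, so at this position the two groups cannot be told apart at the one concentration tested. Within the data shown here, the second step, methoxy in place of hydrogen on an aromatic carbon with the fluoro held fixed, reads as no change at the digits printed from compound 1 to compound 3 (within the scatter) and is the first single-point reading of that change, which the earlier pair, differing in more than one place, could not give. No measurement is available that would account for these flat steps.

As far as these compounds go, the three compounds cover only methyl and fluoro at the one position and hydrogen and methoxy at the other, so it stays open whether an amine, a carboxylic acid or a longer alkyl chain at either place would move the inhibition beyond the scatter. Also open, from the compounds shown here alone, is what a carbonyl oxygen in place of the sulfur on the shared core would do to this read-out.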